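The source may hold more compounds than are shown below. What is called first, only, known or untested is meant among the compounds shown, and "the series" means these compounds.

Compound 1, with structure `Cc1ccc(C(=O)CC(=O)OC(C)Cn2cnc3c2c(=O)n(C)c(=O)n3C)cc1`, is one of three compounds tested in a functional assay on CCRF-CEM cells (Homo sapiens) for antiproliferative activity, read by MTT assay, with a stated time of 72 h, tested at 50 uM; a lower number here means a stronger effect, a higher number a weaker effect of the compound at the concentration tested. In this assay compound 1 gives 74.2%, the highest number among the three and thus the weakest effect. Compound 3, with structure `COC(C(=O)OC(C)Cn1cnc2c1c(=O)n(C)c(=O)n2C)c1ccc2ccccc2c1`, gives 28.2% in this assay, a number well below that of compound 1 and beyond the usual scatter. Compound 2, with structure `CC(Cn1cnc2c1c(=O)n(C)c(=O)n2C)OCc1cn(CCCn2nc3c(Br)c(Br)c(Br)c(Br)c3n2)nn1`, gives 0% in this assay, the furthest below compound 1 of the three. No pair of these compounds differs in only one place, so no single-change step can be read from them.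

Compound 4, with structure `CC(Cn1cnc2c1c(=O)n(C)c(=O)n2C)OC(=O)CC(=O)c1ccc(F)cc1`, is not yet measured. Compound 4 differs from compound 1 by fluoro in place of methyl on an aromatic carbon. The change keeps the heavy-atom count and the set of donors and acceptors unchanged, and the shared core is untouched. A step of no size beyond the scatter is expected in this assay, with no clear direction, as the step of a number 2.2 percentage points lower from compound 1 to compound 4 (within the scatter) expresses. Compound 4 is therefore estimated to give about 72% in this assay, within a range from 52% to 92%.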

Compound 4, a percentage reported as activity, at one concentration (the size of the read-out at that concentration, not a potency): 51.1%
The estimate for compound 4 lay 20.9 percentage points above the measured number, and the stated range ends above it.
By their numbers in this assay, from the lowest: compound 2; then compound 3; then compound 4; then compound 1.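

Among the compounds shown here, the pair gives the first single-change step: in this assay, fluoro in place of methyl on an aromatic carbon, para to a large group, gives a number 23.1 percentage points lower from compound 1 to compound 4 (beyond the scatter) and so counts as a modest step toward a stronger effect at the concentration tested. This place on the six-membered aromatic ring is therefore not indifferent to the group it carries, even though the change leaves the heavy-atom count and the hydrogen-bond donors and acceptors as they were. Nothing measured here explains why 4-fluorophenyl and 4-methylphenyl differ in this way.

From the compounds shown here alone, whether chloro, methoxy or an amine at the same place would push the number further down or bring it back up remains open, as does whether the step would hold on a longer chain. Compound 2 and compound 3 differ from compound 1 and compound 4 in more than one place, so steps to them cannot be read.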